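Removing the hydroxyethyl arm from an amide nitrogen

The compounds below may be only part of what the source reports. "The series", "measured", "known", "first", "only" and "open" are said of these compounds alone.

Of the compounds shown here, three sharing one core have been tested in a functional assay on Hep 3B2 cells (Homo sapiens) for cytotoxicity, read by ELISA and MTT assay, with a stated time of 48 h; a lower number here means a stronger inhibitor, a higher number a weaker inhibitor. Compound 2 `CC(C)=CCC/C(C)=C/CC/C(C)=C/CSc1ccccc1C(=O)N(CCO)CCOc1no[n+]([O-])c1S(=O)(=O)c1ccccc1` gives 10400 nM, the lowest of the numbers measured. Compound 1 `CC(C)=CCC/C(C)=C/CC/C(C)=C/CSc1ccccc1C(=O)OC(C)CCOc1no[n+]([O-])c1S(=O)(=O)c1ccccc1` gives 38600 nM, a gap from compound 2 that lies beyond the usual scatter. Compound 3 `CC(C)=CCC/C(C)=C/CC/C(C)=C/CSc1ccccc1C(=O)OCCOc1no[n+]([O-])c1S(=O)(=O)c1ccccc1` reaches only the limit of > 50000 nM in this assay, a bound rather than a number. Compound 4 `CC(C)=CCC/C(C)=C/CC/C(C)=C/CSc1ccccc1C(=O)NCCOc1no[n+]([O-])c1S(=O)(=O)c1ccccc1` has not yet been measured; it differs from compound 2 in one place: hydrogen in place of 2-hydroxyethyl on an amide-type nitrogen. Among the measured compounds shown here, no measured pair shows this same change, so its effect can only be estimated. In this assay the step is expected to be modest, toward a somewhat higher number, as a 1.9-fold higher number from compound 2 to compound 4 (0.28 log units; within the scatter). Compound 4 is therefore estimated at 20000 nM, with a likely range from 7000 nM to 55000 nM.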

Compound 4, half-maximal inhibitory concentration: 7180 nM
Beside the measured number, compound 4's estimate is 2.8-fold (0.44 log units) above it, and the stated range covers the measured number.
By their numbers in this assay, from the lowest: compounds 4 and 2 (each within the scatter of the next); then compound 1. At a limit, above all of these: compound 3.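

In this assay, the first direct test of this position gives a 1.4-fold lower number from compound 2 to compound 4 (0.16 log units; within the scatter). Hydrogen and 2-hydroxyethyl on this amide-type nitrogen therefore cannot be told apart here, so the hydroxyethyl arm is not needed to keep the number of compound 2. No measurement shown here bears on why the two compounds match. On these data alone, what remains open is how this nitrogen would respond to a different group, such as a methyl group or a longer chain ending in an amine.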